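From methoxymethoxy to hydroxy on the shared core

The source may report more compounds than this note shows. Statements on the series, on what has been measured and on what is new or still open speak of the compounds shown alone.

Measured in an ADME assay on HT-29 cells (Homo sapiens) for cytotoxicity, read by MTT assay, with a stated time of 72 h; a lower number here means a stronger inhibitor, a higher number a weaker inhibitor:
Compound 1 `COc1ccc(C2=C(c3cc(OC)c(OC)c(OC)c3)C(=O)CC2O[SiH2]C(C)(C)C)cc1`: > 100 ug/mL (a limit of the assay)
Compound 2 `COC(=O)c1cc(C2=C(c3cc(OC)c(OC)c(OC)c3)C(=O)CC2O[SiH2]C(C)(C)C)ccc1OC`: > 100 ug/mL (a limit of the assay)
Compound 3 `COCOc1cc(C2=C(c3cc(OC)c(OC)c(OC)c3)C(=O)CC2O[SiH2]C(C)(C)C)ccc1OC`: 43 ug/mL

Going by the values given here, compound 3 gives 43 ug/mL in this assay as the only true number in the set. The other two values are limits. The compound still to be measured is compound 4 `COc1ccc(C2=C(c3cc(OC)c(OC)c(OC)c3)C(=O)CC2O[SiH2]C(C)(C)C)cc1O`. It differs from compound 3 by a single change, (hydrogen in place of methoxymethyl on an oxygen on an aromatic ring), in which hydrogen takes the place of methoxymethyl on an oxygen on an aromatic ring, turning methoxymethoxy into hydroxy.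

Among the compounds with values here, two measured steps bear on this change. One is an at least 2.3-fold lower number from compound 1 to compound 3 (0.36 log units; beyond the scatter) and the other is an at least 2.3-fold lower number from compound 2 to compound 3 (0.36 log units; beyond the scatter). Both involve the arrival of methoxymethoxy, and both sizes are bounded by limits. The third, a step that the two limits leave unreadable from compound 1 to compound 2, offers no guide. Within the data shown here, no measured compound carries the hydroxy group, so the evidence is indirect.

Compound 4 keeps the oxygen of compound 3, which sits at 43 ug/mL, so a number rather than a limit is expected, and probably a moderately lower one. The expected change is a 3.6-fold lower number from compound 3 to compound 4 (0.55 log units; beyond the scatter). The estimate for compound 4 is 12 ug/mL, with an expected range from 0.8 ug/mL to 90 ug/mL.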

Compound 4, half-maximal inhibitory concentration: 38 ug/mL
Compound 4: the middle estimate sits 3.2-fold (0.50 log units) below what was measured; the range from low to high includes it.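

In this assay the loss of the methoxymethyl group from the oxygen on the aromatic ring leaves the reading essentially unchanged, with a 1.1-fold lower number from compound 3 to compound 4 (0.05 log units; within the scatter). The earlier compounds shown here tied the gain to methoxymethoxy alone, whereas this result shows that the whole group is not needed: hydroxy and methoxymethoxy cannot be told apart here, so a bare oxygen substituent at this place is enough for a measurable number. Hydroxy also stands clear of the other two groups, with an at least 2.6-fold lower number from compound 1 to compound 4 (0.42 log units; beyond the scatter) and an at least 2.6-fold lower number from compound 2 to compound 4 (0.42 log units; beyond the scatter), though these two steps give only a smallest size, as the values of compound 1 and compound 2 are limits: the limit of > 100 ug/mL in this assay, at which 2 of the 4 values shown sit.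

As far as these compounds go, what remains open is whether the oxygen itself matters or whether other groups at this place would do the same, which an amine, a carboxylic acid or a longer ether chain such as ethoxy could help to decide. From the compounds shown here alone, the true sizes of the steps from the two limit compounds also stay unknown, and every comparison here rests on the shared core and this single assay.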